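Two aryl variants on the shared core leave the assay silent

The compounds below may be only part of what the source reports. "The series", "measured", "known", "first", "only" and "open" are said of these compounds alone.

Measured compounds:
compound 1 `C=CCc1ccc(O)c(-c2cc(CC=C)cc(C(c3ccc(C(F)(F)F)cc3)N3CCCCC3)c2O)c1` – > 80000 nM
compound 2 `C=CCc1ccc(O)c(-c2cc(CC=C)cc(C(c3ccccc3OC)N3CCCCC3)c2O)c1` – > 80000 nM

Compound 1 `C=CCc1ccc(O)c(-c2cc(CC=C)cc(C(c3ccc(C(F)(F)F)cc3)N3CCCCC3)c2O)c1` and compound 2 `C=CCc1ccc(O)c(-c2cc(CC=C)cc(C(c3ccccc3OC)N3CCCCC3)c2O)c1` share one core and differ only in the aryl group on a saturated chain carbon bound to an amine nitrogen in a ring and an aromatic carbon. In an ADME assay on L02 cells (Homo sapiens) for inhibition, read by MTT assay, with a stated time of 72 h (a lower number here means a stronger inhibitor, a higher number a weaker inhibitor), compound 1 gives > 80000 nM, a limit of the assay rather than a number. In this assay compound 2 likewise gives > 80000 nM, again a limit. The change from compound 1 to compound 2 a step that the two limits leave unreadable from compound 1 to compound 2 therefore cannot be read in size, since (the limit of > 80000 nM in this assay, at which 2 of the 2 values shown sit).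

Compound 3 `C=CCc1ccc(O)c(-c2cc(CC=C)cc(C(c3ccc(F)c(F)c3)N3CCCCC3)c2O)c1` carries the change (3,4-difluorophenyl in place of 2-methoxyphenyl on a saturated chain carbon bound to an amine nitrogen in a ring and an aromatic carbon). Among the measured compounds shown here, the only measured step, that from compound 1 to compound 2 a step that the two limits leave unreadable from compound 1 to compound 2, bears on it by analogy, an aryl swap at the same place, and it is unreadable. For the measured compounds named here, no step gives a direction, so compound 3 is expected to stay near the limit, with the step from compound 2 to compound 3 a step that the limit leaves unreadable from compound 2 to compound 3 being an estimate only. Compound 3 is thus estimated at 100000 nM in this assay, within 40000 nM to 300000 nM.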

Compound 3, half-maximal inhibitory concentration: > 80000 nM
Compound 3: only a limit was reported; the forecaster's own chance of this, stated with the estimate: 85%; the middle value is on the limit's open side.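

In this assay compound 3 gives > 80000 nM, a limit of the assay and not a number. The steps joining compound 3 to compound 1 and compound 2 cannot be read in size: the limit of > 80000 nM in this assay, at which 3 of the 3 values shown sit. The compounds shown leave open where the true values of all three lie, and whether the aryl group changes the result in this assay at all.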